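This account rests on a few compounds, and the source may have more. Where it says the series, first, only, none or still open, it means among the compounds named here.

Measured compounds:

Compound 1, `CS(=O)(=O)Nc1cccc2c1CCC2c1ncc[nH]1` — in a functional assay on CHO cells for agonist activity at Alpha-1B adrenergic receptor (Homo sapiens), read by FLIPR and calcium flux (on this read-out lower numbers stand for an effect already at smaller amounts and higher numbers for an effect only at larger amounts of compound), compound 1 reaches only the limit of > 10000 nM.
Compound 2, `Cc1ccc2c(c1NS(C)(=O)=O)CCC2c1ncc[nH]1` — in this assay compound 2 also reaches only the limit of > 10000 nM.
Compound 3, `CS(=O)(=O)Nc1c(Cl)ccc2c1CCCC2c1ncc[nH]1` — in this assay compound 3 likewise reaches only the limit of > 10000 nM.

Compound 1 therefore stands at the limit of this assay, not at a number, and so do its two neighbours: the limit of > 10000 nM in this assay, at which 3 of the 3 values shown sit. Among the measured compounds shown here, the only one-place step among them, a step that the two limits leave unreadable from compound 1 to compound 2, is unreadable for the same reason, so nothing measured yet tells how much any change moves the read-out.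

The step to compound 4, `c1cncc(-c2cccc3c2CCC3c2ncc[nH]2)c1`, exchanges one group: pyridin-3-yl in place of methanesulfonamido on an aromatic carbon. For the measured compounds named here, no measured step bears on this exchange; the one step at hand, from compound 1 to compound 2, leaves no size that can be read off. Three compounds at the limit give little ground for expecting a clear effect, and an estimate can only lean toward the same outcome. For compound 4 in this assay the expected value is 8000 nM, within a range from 800 nM to 30000 nM. The expected step from compound 1 to compound 4 is an at least 1.2-fold lower number from compound 1 to compound 4 (0.09 log units; that floor lies within the scatter).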

Compound 4, half-maximal effective concentration: > 10000 nM
Compound 4: a limit, no number; the forecaster's own chance of this, stated with the estimate: 60%; middle value at least 1.2-fold (0.09 log units) from the limit.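

Compound 4 gives only a limit, as compound 1 does, so no size can be read for the step between them: the limit of > 10000 nM in this assay, at which 4 of the 4 values shown sit. The compounds shown leave open whether any change to the core of compound 1 gives a true number in this assay.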